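The compounds below may be only part of what the source reports. "The series", "measured", "known", "first", "only" and "open" are said of these compounds alone.

Compounds measured:
- compound 1, `C[C@]1(c2ccccc2)OCC[C@H](CCNCc2ccccc2)O1`, 11 nM
- compound 2, `c1ccc(CNCC[C@@H]2CCO[C@H](c3ccccc3)O2)cc1`, 6 nM

In an assay on brain for displacement of a labelled ligand from Sigma non-opioid intracellular receptor 1 (Cavia porcellus) (a lower number here means a stronger inhibitor, a higher number a weaker inhibitor), compound 2 gives 6 nM, the lowest of the two numbers, and compound 1 gives 11 nM, which lies within the scatter of compound 2; the two values tell nothing apart.

Compound 3, `c1ccc(CNCC[C@H]2CCO[C@@H](c3ccccc3)O2)cc1`, is the mirror image of compound 2: the two compounds have the same atoms and bonds and differ only in configuration as drawn: 2 of 2 stereo elements differ (all stereocentres are inverted: mirror images); a stereocentre at a saturated ring carbon is drawn R in compound 2 and S in compound 3; a stereocentre at a saturated ring carbon is drawn S in compound 2 and R in compound 3. For the measured compounds named here, no measured pair in this set shows what inverting these two ring stereocentres does, so the size of the step is open. The account expects a modest weakening in this assay , since mirror images often separate in this way, but a step no larger than the scatter is also possible. Compound 3 is therefore estimated at 18 nM, with a range from 4 nM to 90 nM. The step this means is expected to be a 3.0-fold higher number from compound 2 to compound 3 (0.48 log units; beyond the scatter).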

Compound 3, inhibition constant: 50 nM
Compound 3: the middle estimate sits 2.8-fold (0.44 log units) below what was measured, and the stated range covers the measured number.
By their numbers in this assay, from the lowest: compounds 2 and 1 (each within the scatter of the next); then compound 3.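

Inverting both ring stereocentres gives an 8.3-fold higher number from compound 2 to compound 3 (0.92 log units; beyond the scatter) in this assay, so the configuration at these positions can change the number by more than the scatter, which compound 1 and compound 2 alone could not show. With hydrogen in place of methyl on a saturated ring carbon, the change in this assay is a 4.5-fold higher number from compound 1 to compound 3 (0.66 log units; beyond the scatter), so this ring carbon also responds to what it carries, with the methyl-bearing compound 1 giving the lower number. The step to compound 3 from its mirror image can be put down to configuration alone because of one fact: the fact that compounds 2 and 3 differ only in the configuration as drawn

Which of the two stereocentres carries that step stays open, since both invert together in compound 3. Also open, from the compounds shown here alone, is what an ethyl group or a longer chain would do in place of that methyl.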